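The source may report more compounds than this note shows. Statements on the series, on what has been measured and on what is new or still open speak of the compounds shown alone.

Measured so far in a functional assay on Shh Light II cells (Mus musculus) for inhibition, read by a luciferase reporter; on this read-out higher numbers stand for weaker inhibition and lower numbers for stronger inhibition:
- compound 1 `O=C(Nc1ccccc1Cl)N1CCC(c2nc(-c3ccc4ccccc4n3)no2)CC1`: 510 nM
- compound 2 `O=C(NC1CCC(O)CC1)N1CCC(c2nc(-c3ccc4ccccc4n3)no2)CC1`: 2700 nM
- compound 3 `O=C(NCC1CCC1)N1CCC(c2nc(-c3ccc4ccccc4n3)no2)CC1`: 410 nM

Compound 3 stands at the low end of these numbers, a place it shares. The data show a 1.2-fold lower number from compound 1 to compound 3 (0.09 log units; within the scatter) and a 6.6-fold lower number from compound 2 to compound 3 (0.82 log units; beyond the scatter).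

Compound 4 `O=C(OC1CCCCC1)N1CCC(c2nc(-c3ccc4ccccc4n3)no2)CC1` carries cyclohexyloxy in place of (cyclobutylmethyl)amino on a carbonyl carbon. The measured steps bear on this only indirectly, since none exchanges the amino group for an oxy group. Besides those above, they include a 5.3-fold higher number from compound 1 to compound 2 (0.72 log units; beyond the scatter). Only a rough expectation follows in this assay, with no step beyond the scatter anticipated.

The expected change is a 1.0-fold lower number from compound 3 to compound 4 (0.01 log units; within the scatter). The estimate for compound 4 is 400 nM, with an expected range of 130 nM to 1200 nM.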

Compound 4, half-maximal inhibitory concentration: 580 nM
The estimate for compound 4 lay 1.5-fold (0.16 log units) below the measured number; the range from low to high includes it.
By their numbers in this assay, from the lowest: compounds 3, 1 and 4 (each within the scatter of the next); then compound 2.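

In this assay, an oxygen-linked group on the carbonyl carbon proves compatible with inhibition in the range of the amino-linked groups, without the amide hydrogen: a 1.4-fold higher number from compound 3 to compound 4 (0.15 log units; within the scatter) and a 1.1-fold higher number from compound 1 to compound 4 (0.06 log units; within the scatter) both stay within the scatter. The unsubstituted cyclohexyloxy group also stands clear of the hydroxylated amino group, with a 4.7-fold lower number from compound 2 to compound 4 (0.67 log units; beyond the scatter) beyond the scatter. No evidence here speaks to the origin of these results.

The compounds shown leave open how cyclohexylamino on the same carbonyl carbon would compare with cyclohexyloxy, isolating the linking atom. On these data alone, whether benzyloxy would stay in this range also remains open.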